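Cytotoxicity in BJ cells: from compound 3 to compound 4

The compounds below may be only part of what the source reports. "The series", "measured", "known", "first", "only" and "open" are said of these compounds alone.

The measured compounds are:
Compound 1, `COc1cc2ncnc(-n3nc(-c4ccc(Cl)cc4)nc3N)c2cc1OC`, gives > 50000 nM in an ADME assay on BJ cells (Homo sapiens) for cytotoxicity, with a stated time of 72 h (on this read-out higher numbers stand for an effect only at larger amounts of compound and lower numbers for an effect already at smaller amounts), which is a limit of the assay.
Compound 2, `COc1cc2nc(Cl)nc(-n3nc(-c4ccccn4)nc3N)c2cc1OC`, gives > 13000 nM in this assay, again a limit.
Compound 3, `COc1cc2ncnc(-n3nc(-c4ccccn4)nc3N)c2cc1OCCCN(C)C`, gives > 25000 nM in this assay, also a limit.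

None of the three compounds reaches a number in this assay. Compound 3 therefore stands at a limit, as do the other two, and the three limits sit at different places, recorded in the limit of > 13000 nM in this assay, at which 1 of the 3 values shown sits, the limit of > 25000 nM in this assay, at which 1 of the 3 values shown sits, and (the limit of > 50000 nM in this assay, at which 1 of the 3 values shown sits). Among the compounds with values here, no step between measured compounds exists on which a comparison could rest.

Compound 4, `COc1cc2ncnc(-n3nc(-c4ccccn4)nc3N)c2cc1OCCCNC(=O)OCC(F)(F)F`, is the one not yet measured. It differs from compound 3 in one place: ((2,2,2-trifluoroethoxy)carbonyl)amino in place of dimethylamino on a saturated chain carbon, three bonds along the chain from an oxygen on an aromatic ring.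

Within the data shown here, with every measured value being a limit, there is no step on which a direction could be read. The expectation for compound 4 is that this assay again returns a limit, with the step from compound 3 expected as a step that the limit leaves unreadable from compound 3 to compound 4, which is none beyond the scatter. Compound 4 is estimated at 40000 nM, within a range from 15000 nM to 100000 nM.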

Compound 4, half-maximal effective concentration: > 11000 nM
Compound 4 was reported as a limit; the forecaster's own chance of this, stated with the estimate: 80%; the middle value does not contradict the limit.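

In this assay compound 4 gives > 11000 nM, which is a limit. Within the data shown here, compound 3 gives > 25000 nM, also a limit, so no step from one to the other can be read. The compounds shown leave open at what concentration any of them reaches a half-maximal effect, and whether exchanging dimethylamino for ((2,2,2-trifluoroethoxy)carbonyl)amino shifts it.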